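The source may hold more compounds than are shown below. What is called first, only, known or untested is meant among the compounds shown, and "the series" means these compounds.

Measured so far in a functional assay on the whole organism (strain Wistar) for inhibition, with Rattus norvegicus as the target, read by paw edema, with stated times of 60 min and 2 h, at a dose of 100 mg/kg by the oral route; on this read-out higher numbers stand for more inhibition at the one dose given (going by the name of the read-out) and lower numbers for less inhibition:
compound 1 `CNC(=O)CC1CCc2cc(OC)c(OC)cc21`: 30%
compound 2 `CCCNC(=O)CC1CCc2cc(OC)c(OC)cc21`: 28%
compound 3 `CCCCCNC(=O)CC1CCc2cc(OC)c(OC)cc21`: 34%

Compound 3 holds the highest of the three numbers, yet both gaps to it stay within the scatter: a number 4 percentage points higher from compound 1 to compound 3 (within the scatter) and a number 6 percentage points higher from compound 2 to compound 3 (within the scatter); likewise a number 2 percentage points lower from compound 1 to compound 2 (within the scatter). Lengthening the chain on the amide nitrogen has so far moved nothing beyond the scatter.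

Compound 4 `COc1cc2c(cc1OC)C(CC(=O)N1CCCCC1)CC2` differs from compound 3 in one place: piperidin-1-yl in place of pentylamino on a carbonyl carbon. The change brings in a six-membered non-aromatic ring and takes away the one hydrogen-bond donor. Within the data shown here, no measured pair shows a change of this kind, so nothing bears on it directly; the measured steps only show that the group on the amide nitrogen has not mattered within the scatter. On that basis no step beyond the scatter is expected: a number 2 percentage points lower from compound 3 to compound 4 (within the scatter). Compound 4 is estimated at 32%, between 20% and 44%.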

Compound 4, a percentage reported as inhibition, in the whole organism at one dose (the size of the read-out at that dose, not a potency): 22%
Compound 4: middle estimate off by 10 percentage points, on the high side, and the stated range covers the measured number.
By their numbers in this assay, from the lowest: compounds 4, 2, 1 and 3 (each within the scatter of the next, the first and the last beyond it).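

In this assay the group on the carbonyl carbon now gives a step beyond the scatter, with a number 12 percentage points lower from compound 3 to compound 4 (beyond the scatter) for piperidin-1-yl in place of pentylamino. Against the shorter chains the same ring stays within the scatter, with a number 6 percentage points lower from compound 2 to compound 4 (within the scatter) for propylamino and a number 8 percentage points lower from compound 1 to compound 4 (within the scatter) for methylamino. No evidence at hand explains the step.

As far as these compounds go, whether the step goes with the ring or with the missing amide hydrogen stays open. A diethylamino group on the carbonyl carbon would separate the two.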